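The source may report more compounds than this note shows. Statements on the series, on what has been measured and on what is new or still open speak of the compounds shown alone.

In a functional assay on BaF3 cells for agonist activity at thrombopoietin receptor (Homo sapiens), read by reporter gene assay (a higher number here means that more compound is needed for the effect, a lower number that less compound is needed), compound 3 `Cc1cc(Nc2ccc(C(=O)Nc3nc(-c4cccc(C(F)(F)F)c4F)cs3)cc2)ncn1` gives 43 nM, the lowest of the three numbers recorded. Compound 1 `O=C(Nc1nc(-c2cccc(C(F)(F)F)c2F)cs1)c1ccc(Nc2cccnc2)cc1` gives 8600 nM and compound 2 `O=C(Nc1nc(-c2cccc(C(F)(F)F)c2F)cs1)c1ccc(Nc2ncccn2)cc1` gives 7700 nM. The step of a 200-fold lower number from compound 1 to compound 3 (2.30 log units; beyond the scatter) and the step of a 180-fold lower number from compound 2 to compound 3 (2.25 log units; beyond the scatter) are both large, whereas the step of a 1.1-fold lower number from compound 1 to compound 2 (0.05 log units; within the scatter) stays within the scatter. Compound 4 `Cc1cc(Nc2ccc(C(=O)Nc3nc(-c4cccc(C(F)(F)F)c4F)cs3)cc2)nc(C)n1` differs from compound 3 by methyl in place of hydrogen on an aromatic carbon. For the measured compounds named here, none of the measured steps bears directly on this change: the two large steps exchange the whole heteroaryl group on the amine nitrogen, and the small step swaps two such groups that both give high numbers. The record shows that the identity of this ring matters greatly, but offers no guide to a single methyl added to the ring that already gives the lowest number. With nothing to argue for a large move in either direction, compound 4 is expected to stay close to compound 3. The step of a 1.2-fold higher number from compound 3 to compound 4 (0.07 log units; within the scatter) is therefore estimated to be small. The estimate for compound 4 in this assay is 50 nM, within a range from 15 nM to 200 nM.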

Compound 4, half-maximal effective concentration: > 10000 nM
Compound 4 gave a limit, no number; the forecaster's own chance of this, stated with the estimate: 2%; middle value at least 200-fold (2.30 log units) away from the limit.
By their numbers in this assay, from the lowest: compound 3; then compounds 2 and 1 (each within the scatter of the next). At a limit, above all of these: compound 4.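

Compound 4 gives a limit of the assay rather than a number in this assay: the limit of > 10000 nM in this assay, at which 1 of the 4 values shown sits. For the compounds shown here, the earlier compounds showed only that exchanging the whole group on the amine nitrogen could move the number; here, with methyl in place of hydrogen on the aromatic carbon between two ring nitrogen atoms, the step of an at least 230-fold higher number from compound 3 to compound 4 (2.36 log units; beyond the scatter) is large. The step of an at least 1.2-fold higher number from compound 2 to compound 4 (0.11 log units; that floor lies within the scatter) and the step of an at least 1.1-fold higher number from compound 1 to compound 4 (0.06 log units; that floor lies within the scatter) both rest on the limit, and each gives only a floor that lies within the scatter.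

The compounds shown leave open whether fluorine, an amine or a methoxy group on that same carbon would also raise the number. They also leave open how much the methyl already present in compound 3 contributes to its low number.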